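Nitro to fluoro on the anilino ring: compound 4

The compounds below may be only part of what the source reports. "The series", "measured", "known", "first", "only" and "open" are said of these compounds alone.

Measured so far:
compound 1 `Cc1cnc(Nc2ccc([N+](=O)[O-])cc2)nc1Nc1nc2ccccc2s1` — 34300 nM
compound 2 `Cc1cnc(Nc2ccc(S(C)(=O)=O)cc2)nc1Nc1nc2ccc(F)cc2s1` — > 50000 nM (a limit, not a number)
compound 3 `Cc1cnc(Nc2ccc(S(N)(=O)=O)cc2)nc1Nc1nc2ccc(F)cc2s1` — 3460 nM

In a functional assay on HeLa cells (Homo sapiens) for antiproliferative activity, read by MTT assay, with a stated time of 48 h (on this read-out higher numbers stand for weaker inhibition and lower numbers for stronger inhibition), compound 1 gives 34300 nM, the higher of the two numbers shown, while compound 3 gives 3460 nM. Compound 2 reaches only the limit > 50000 nM and yields no number; see (the limit of > 50000 nM in this assay, at which 1 of the 3 values shown sits). Among the compounds with values here, the single measured step, an at least 14-fold lower number from compound 2 to compound 3 (1.15 log units; beyond the scatter), concerns the sulfonyl group, not the position now changed. Compound 4 `Cc1cnc(Nc2ccc(F)cc2)nc1Nc1nc2ccccc2s1` differs from compound 1 by fluoro in place of nitro on an aromatic carbon. Within the data shown here, no measured step touches this change, so no direction can be drawn from the data; a number near that of compound 1 is expected, with a wide range. Compound 4 is therefore estimated at 40000 nM (from 12000 nM to 150000 nM), an expected step of a 1.2-fold higher number from compound 1 to compound 4 (0.07 log units; within the scatter) that should stay within the scatter.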

Compound 4, half-maximal inhibitory concentration: > 50000 nM
Compound 4: a limit, no number; the forecaster's own chance of this, stated with the estimate: 35%; at least 1.2-fold (0.09 log units) between middle value and limit.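

Within the data shown here, this is the only measured step at this position: in this assay, fluoro in place of nitro on an aromatic carbon gives an at least 1.4-fold higher number from compound 1 to compound 4 (0.16 log units; that floor lies within the scatter). The entry for compound 4 is a limit and not a number, so the step is only a floor; it shows no sign that fluoro lowers the number relative to nitro. Compound 4 is not alone in this: the limit of > 50000 nM in this assay, at which 2 of the 4 values shown sit.

From the compounds shown here alone, whether an amine or a carboxylic acid at this place would give a measurable number remains open. So does whether the sulfonyl step seen with amino in place of methyl would hold on the core of compound 1.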